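Trading a pyrrolidine chain for a propargyl ether

The compounds below may be only part of what the source reports. "The series", "measured", "known", "first", "only" and "open" are said of these compounds alone.

Of the compounds shown here, three have been measured so far in a physicochemical assay for lipophilicity, using the shake flask method; a lower number here means a more polar compound, a higher number a more lipophilic compound. Compound 1 `Nc1ncnc(Oc2ccc(NC(=O)C3(C(=O)Nc4ccc(F)cc4)CC3)cc2F)c1/C=N/OCCO` gives 2.37, compound 2 `CC(O)CO/N=C/c1c(N)ncnc1Oc1ccc(NC(=O)C2(C(=O)Nc3ccc(F)cc3)CC2)cc1F` gives 2.75, and compound 3 `Nc1ncnc(Oc2ccc(NC(=O)C3(C(=O)Nc4ccc(F)cc4)CC3)cc2F)c1/C=N/OCCCN1CCCC1` gives 3.82. Compound 3 stands highest of the three: its nearest neighbour is compound 2, and the gap a number 1.07 log units higher from compound 2 to compound 3 (beyond the scatter) lies beyond the scatter, as does the larger gap a number 1.45 log units higher from compound 1 to compound 3 (beyond the scatter). The smaller step of a number 0.38 log units higher from compound 1 to compound 2 (beyond the scatter) is modest but still beyond the scatter.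

Compound 4 `C#CCO/N=C/c1c(N)ncnc1Oc1ccc(NC(=O)C2(C(=O)Nc3ccc(F)cc3)CC2)cc1F` has not yet been measured. It differs from compound 3 in one place: ethynyl in place of 2-(pyrrolidin-1-yl)ethyl on a saturated chain carbon bound to an oxygen

Within the data shown here, the steps that bear on this change run in the opposite direction. Going from compound 1 to compound 3 and from compound 2 to compound 3, attaching the pyrrolidine chain raised the value by a large amount each time. Compound 4 removes that chain but does not bring back the hydroxy of compound 1 or compound 2, so only part of that rise is expected to be given back. The step from compound 3 to compound 4 is therefore expected to be a moderate fall, a number 0.62 log units lower from compound 3 to compound 4 (beyond the scatter), beyond the scatter. On that basis compound 4 is estimated at 3.2, with a likely range from 2.7 to 3.7.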

Compound 4, partition coefficient: 3.34
Beside the measured number, compound 4's estimate is 0.14 log units below it; the range from low to high includes it.
By their numbers in this assay, from the lowest: compound 1; then compound 2; then compound 4; then compound 3.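

In this assay, the chain at this position can carry neither a hydroxy nor a pyrrolidine and still give a value between those of the two kinds of chain. Removing the 2-(pyrrolidin-1-yl)ethyl in favour of ethynyl gives a number 0.48 log units lower from compound 3 to compound 4 (beyond the scatter) and yet leaves compound 4 above both hydroxy compounds, with a number 0.59 log units higher from compound 2 to compound 4 (beyond the scatter) and a number 0.97 log units higher from compound 1 to compound 4 (beyond the scatter) as the other two steps, so the earlier gap between hydroxy chains and the pyrrolidine chain now has a measured point inside it. Nothing at hand explains the size or direction of these steps. What the compounds shown leave open is how much of the change belongs to the triple bond itself, which a saturated propyl chain on the same oxygen would help to separate from the loss of the pyrrolidine. Also open, on these data alone, is whether a morpholine or a dimethylamino group at the end of the chain, or a longer chain ending in an alkyne, would follow the same order.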